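A few compounds are considered here, and "the series" means these few. Any claim that something is new, unique, unknown or untested is made for them only; others in the source may bear on it.

The study measures antiproliferative activity in a functional assay on HepG2 cells (Homo sapiens) for antiproliferative activity, read by MTT assay, with a stated time of 72 h; a lower number here means a stronger inhibitor, a higher number a weaker inhibitor. Compound 1, with structure `O=C1COc2ccc(-c3cccc(NS(=O)(=O)c4ccc(F)cc4)c3)cc2N1C1CC1`, is one of three compounds reported there. In this assay compound 1 gives > 40000 nM, which is a limit of the assay rather than a number. Two other compounds accompany it. Compound 2, with structure `O=C1COc2ccc(-c3cnc(Cl)c(NS(=O)(=O)c4ccc(F)cc4)c3)cc2N1c1ccccc1`, gives 35700 nM in this assay. Compound 3, with structure `O=C1COc2ccc(-c3cnc4ccccc4c3)cc2N1c1ccccc1`, gives > 40000 nM in this assay, again a limit of the assay and not a number. Compound 1 therefore stands at the limit of > 40000 nM in this assay, at which 2 of the 3 values shown sit; no shown value sets it apart from the others, and no step between measured compounds is recorded, so the data offer no measured precedent for any change at the amide-type nitrogen.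

The unmeasured compound 4, with structure `CC(C)N1C(=O)COc2ccc(-c3cccc(NS(=O)(=O)c4ccc(F)cc4)c3)cc21`, differs from compound 1 in one place: isopropyl in place of cyclopropyl on an amide-type nitrogen in a ring. The incoming group carries no donor and no acceptor, just as the outgoing one. With compound 1 resting at a limit, nothing in the shown data points toward a gain in this assay. The step is expected to amount to a number no higher from compound 1 to compound 4 (the limit leaves the size open), that is, nothing beyond the scatter. Compound 4 is accordingly estimated at 40000 nM, within a range from 20000 nM to 80000 nM, and most probably only a limit will be reported.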

Compound 4, half-maximal inhibitory concentration: > 40000 nM
Compound 4 gave a limit, no number; the forecaster's own chance of this, stated with the estimate: 85%; the middle value sits exactly at the limit.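

Compound 1 and compound 4 both rest at a limit of the assay and not at a number, so no step can be read for isopropyl in place of cyclopropyl, and compound 4 joins the others there: the limit of > 40000 nM in this assay, at which 3 of the 4 values shown sit.

The compounds shown leave open whether, in this assay, either group on the amide-type nitrogen in a ring would give a measurable value on this core.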